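Working notes: aryl exchange on a ring amine nitrogen

This account rests on a few compounds, and the source may have more. Where it says the series, first, only, none or still open, it means among the compounds named here.

The series shares one core, carried by compound 1 `CN(C(=S)SCc1ccc(C(=O)Nc2ccccc2N)cc1)c1cccnc1`, compound 2 `N#Cc1ccc(N2CCN(C(=S)SCc3ccc(C(=O)Nc4ccccc4N)cc3)CC2)cc1` and compound 3 `CCN(Cc1ccncc1)C(=S)SCc1ccc(C(=O)Nc2ccccc2N)cc1`. In a functional assay on HeLa cells (Homo sapiens) for antiproliferative activity, read by CCK-8 assay, with a stated time of 72 h, tested at 8 uM (a lower number here means a weaker effect, a higher number a stronger effect of the compound at the concentration tested), compound 1 gives 70.5%, compound 2 gives 70.6% and compound 3 gives 77.7%. The number of compound 2 lies within the usual scatter of both compound 1 and compound 3, so the three values cannot be told apart. Going by the values given here, the only step between compounds that differ in one place is a number 7.2 percentage points higher from compound 1 to compound 3 (within the scatter), and it concerns the substituents on the thiocarbonyl carbon rather than the ring amine nitrogen.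

Compound 4 `Nc1ccccc1NC(=O)c1ccc(CSC(=S)N2CCN(c3cnccn3)CC2)cc1` is not yet measured in this assay. It differs from compound 2 in one place: pyrazin-2-yl in place of 4-cyanophenyl on an amine nitrogen in a ring. Among the compounds with values here, no measured pair changes the group on this ring amine nitrogen, so no step bears directly on it; the one step available lies elsewhere and stayed within the scatter. Within the data shown here, the three numbers so far are close to one another, and nothing points to a move beyond the scatter for compound 4.

Compound 4 is therefore expected to give about 70% in this assay, within 58% to 82%. The step from compound 2 is expected to be a number 0.6 percentage points lower from compound 2 to compound 4 (within the scatter), not beyond the scatter.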

Compound 4, a percentage reported as inhibition, at one concentration (the size of the read-out at that concentration, not a potency): 76.9%
Estimate against measurement, compound 4: 6.9 percentage points below; low and high end bracket the measured number.
By their numbers in this assay, from the lowest: compounds 1, 2, 4 and 3 (each within the scatter of the next).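

Going by these compounds alone, the exchange of 4-cyanophenyl for pyrazin-2-yl on the amine nitrogen in a ring gives, in this assay, a number 6.3 percentage points higher from compound 2 to compound 4 (within the scatter), and this is the first step that can be read at this position. The two groups therefore cannot be told apart here: removing the nitrile and the carbon-only aromatic ring, and bringing in a six-membered aromatic ring with 2 hetero atoms, produces no step beyond the scatter at the one concentration tested. No measurement shown bears on what lies behind this step.

Both groups on this nitrogen are six-membered aromatic rings, so the compounds shown leave open whether a non-aromatic group there, such as a methyl, an acetyl or a longer alkyl chain, or a phenyl carrying a carboxylic acid, would also stay within the scatter of compound 2. They also leave open whether compound 2 and compound 4 would separate in potency, since the read-out gives the size of the effect at a single concentration and not a potency.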